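Nitrofuran to Nitrothiophene on a Second Core

The source may hold more compounds than are shown below. What is called first, only, known or untested is meant among the compounds shown, and "the series" means these compounds.

Compound 1 `CC(C)(C)C1CCN(S(=O)(=O)c2ccc(NC(=O)c3ccc([N+](=O)[O-])o3)cc2)CC1` in an ADME assay on IMR-90 cells (Homo sapiens) for cytotoxicity, read by CellTiter-Blue, with a stated time of 46 h (on this read-out lower numbers stand for an effect already at smaller amounts and higher numbers for an effect only at larger amounts of compound), gives > 25000 nM, a limit of the assay.
Compound 2 `O=C(Nc1ccc(S(=O)(=O)N2CCC3(CCCCC3)CC2)cc1)c1ccc([N+](=O)[O-])o1` in this assay gives > 25000 nM, also a limit.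
Compound 3 `CC(C)(C)C1CCN(S(=O)(=O)c2ccc(NC(=O)c3ccc([N+](=O)[O-])s3)cc2)CC1` in this assay gives > 25000 nM, again a limit.

Compound 3 differs from compound 1 by 5-nitrothiophen-2-yl in place of 5-nitrofuran-2-yl on a carbonyl carbon. The step that the two limits leave unreadable from compound 1 to compound 3 cannot be sized because of the limit of > 25000 nM in this assay, at which 3 of the 3 values shown sit. The cores of compound 1 and compound 2 differ, but that difference is not broken down here. Compound 4 `O=C(Nc1ccc(S(=O)(=O)N2CCC3(CCCCC3)CC2)cc1)c1ccc([N+](=O)[O-])s1` stands to compound 2 as compound 3 stands to compound 1: 5-nitrothiophen-2-yl in place of 5-nitrofuran-2-yl on a carbonyl carbon, the same change at the same place. The step that the limit leaves unreadable from compound 2 to compound 4 is expected to be small, which rests on compound 1 and compound 3 both sitting at the limit, (the limit of > 25000 nM in this assay, at which 3 of the 3 values shown sit). Compound 4 is therefore expected to give 35000 nM, between 15000 nM and 120000 nM, most likely reported only as a limit.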

Compound 4, half-maximal effective concentration: > 25000 nM
Compound 4 ended at the assay's limit; the forecaster's own chance of this, stated with the estimate: 85%; the middle value is on the limit's open side.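

No step can be read from compound 2 to compound 4, because both sit at the same limit: the limit of > 25000 nM in this assay, at which 4 of the 4 values shown sit. The compounds shown leave open how far each lies from that limit, and whether 5-nitrothiophen-2-yl in place of 5-nitrofuran-2-yl changes the read-out at all.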